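Halogen series on L cell cytotoxicity: the fluoro member

The compounds below may be only part of what the source reports. "The series", "measured", "known", "first", "only" and "open" are said of these compounds alone.

Measured compounds:
Compound 1 `NC1CC(n2cc(I)c(=O)[nH]c2=O)OC1CO`: in a functional assay on L929 cells for cytotoxicity against L cells (Mus musculus) (on this read-out higher numbers stand for an effect only at larger amounts of compound and lower numbers for an effect already at smaller amounts), compound 1 reaches only the limit > 100 uM.
Compound 2 `NC1CC(n2cc(Br)c(=O)[nH]c2=O)OC1CO`: in this assay compound 2 likewise reaches only the limit > 100 uM.
Compound 3 `NC1CC(n2cc(Cl)c(=O)[nH]c2=O)OC1CO`: in this assay compound 3 gives 100 uM.

Going by the values given here, compound 3 thus stands as the only number among the three results; the other two are limits. The step from compound 1 to compound 2 is a step that the two limits leave unreadable from compound 1 to compound 2, that from compound 1 to compound 3 is a number no higher from compound 1 to compound 3 (the limit leaves the size open), and that from compound 2 to compound 3 is a number no higher from compound 2 to compound 3 (the limit leaves the size open). Compound 4 `NC1CC(n2cc(F)c(=O)[nH]c2=O)OC1CO` differs from compound 3 by fluoro in place of chloro on an aromatic carbon. All three halogen steps bear on this change, yet none is readable in size because of the limit of > 100 uM in this assay, at which 2 of the 3 values shown sit. Compound 4 is therefore expected near compound 3, at 100 uM with a range of 40 uM to 200 uM. The expected step of no change at the digits printed from compound 3 to compound 4 (within the scatter) is estimated to stay within the scatter.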

Compound 4, concentration for half-maximal effect: 100 uM
Compound 4: middle estimate and measured number agree at the digits printed, and the stated range covers the measured number.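

In this assay fluoro in place of chloro on this aromatic carbon gives no change at the digits printed from compound 3 to compound 4 (within the scatter). Fluoro and chloro at this position therefore cannot be told apart on this read-out. The other two steps are a number no higher from compound 2 to compound 4 (the limit leaves the size open) and a number no higher from compound 1 to compound 4 (the limit leaves the size open). These cannot be read in size, like the earlier steps involving compound 1 and compound 2, for one reason: the limit of > 100 uM in this assay, at which 2 of the 4 values shown sit.

The compounds shown leave open whether iodo or bromo differs from chloro or fluoro here. They also leave open what a methyl group, an amine or a carboxylic acid would do at this position.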